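Chloro to Methyl on the Sulfonamide Aryl Ring

The source may hold more compounds than are shown below. What is called first, only, known or untested is meant among the compounds shown, and "the series" means these compounds.

Compound 3 `O=C1O[C@H]([C@@H](O)Cn2cc(CNS(=O)(=O)c3ccc(Cl)cc3)nn2)C(OCc2ccccc2)=C1OCc1ccccc1` gives the lowest number of the three measured in a functional assay on A549 cells (Homo sapiens) for antiproliferative activity, read by MTT assay, with a stated time of 72 h (a lower number here means a stronger inhibitor, a higher number a weaker inhibitor), at 2870 nM. Compound 1 `CCCCCCCCCCc1cn(C[C@H](O)[C@H]2OC(=O)C(OCc3ccccc3)=C2OCc2ccccc2)nn1` gives 6750 nM, and compound 2 `O=C1O[C@H]([C@@H](O)Cn2cc(C3CC3)nn2)C(OCc2ccccc2)=C1OCc1ccccc1` gives 43900 nM. The two steps that reach compound 3 were a 2.4-fold lower number from compound 1 to compound 3 (0.37 log units; beyond the scatter) and a 15-fold lower number from compound 2 to compound 3 (1.18 log units; beyond the scatter), yet both replace a much larger part of the structure than the change now considered. Compound 4 `Cc1ccc(S(=O)(=O)NCc2cn(C[C@H](O)[C@H]3OC(=O)C(OCc4ccccc4)=C3OCc3ccccc3)nn2)cc1` differs from compound 3 only by methyl in place of chloro on an aromatic carbon. Within the data shown here, no measured step touches that position; the change is expected to stay within the scatter of this assay. Compound 4 is therefore estimated at 3300 nM, with a range from 1200 nM to 9000 nM. This corresponds to an expected step of a 1.1-fold higher number from compound 3 to compound 4 (0.06 log units; within the scatter).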

Compound 4, half-maximal inhibitory concentration: 16800 nM
Estimate against measurement, compound 4: 5.1-fold (0.71 log units) below; measured number above the stated range.
By their numbers in this assay, from the lowest: compound 3; then compound 1; then compound 4; then compound 2.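

In this assay this ring position proves sensitive: exchanging a single heavy atom, chloro for methyl, gives a 5.9-fold higher number from compound 3 to compound 4 (0.77 log units; beyond the scatter) and is not a silent change. With methyl, the sulfonyl arm now ranks behind the decyl group, at a 2.5-fold higher number from compound 1 to compound 4 (0.40 log units; beyond the scatter) and still ahead of the cyclopropyl group, at a 2.6-fold lower number from compound 2 to compound 4 (0.42 log units; beyond the scatter) in this series. The lead of compound 3 therefore rests in part on its chloro. As far as these compounds go, whether a fluoro, a methoxy or a nitrile on this carbon would track chloro or methyl stays open. Nothing available explains this step.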